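Methoxy on Two Sulfur-Linked Cores in MT4 Cells

A few compounds are considered here, and "the series" means these few. Any claim that something is new, unique, unknown or untested is made for them only; others in the source may bear on it.

Compound 1 `N#Cc1c(N)cccc1[S+]([O-])c1cccc(C(F)(F)F)c1` is measured in a functional assay on MT4 cells (Homo sapiens) for cytotoxicity (on this read-out higher numbers stand for weaker inhibition and lower numbers for stronger inhibition), where compound 1 gives 125000 nM. Compound 2 `COc1cc([S+]([O-])c2cccc(N)c2C#N)cc(C(F)(F)F)c1` carries methoxy in place of hydrogen on an aromatic carbon; in this assay compound 2 gives 108000 nM, and the change made a 1.2-fold lower number from compound 1 to compound 2 (0.06 log units; within the scatter). Compound 3 `N#Cc1c(N)cccc1S(=O)(=O)c1ccccc1` is built on another core; the difference between the two cores is not broken down here. For compound 3 in this assay only a limit is known, > 5000 nM. That value is one of those that sit at the limit of > 5000 nM in this assay, at which 1 of the 3 values shown sits. Compound 4 `COc1ccccc1S(=O)(=O)c1cccc(N)c1C#N` is not yet measured; it differs from compound 3 by methoxy in place of hydrogen on an aromatic carbon, the same kind of change as that from compound 1 to compound 2, the place now being ortho to a large group rather than meta to a large group and meta to a trifluoromethyl group. Given a 1.2-fold lower number from compound 1 to compound 2 (0.06 log units; within the scatter), a step of similar size is expected for compound 4, estimated at a step that the limit leaves unreadable from compound 3 to compound 4. Because compound 3 gives > 5000 nM, a limit is also likely for compound 4. Compound 4 is estimated at 60000 nM, expected between 8000 nM and 300000 nM.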

Compound 4, half-maximal inhibitory concentration: 146000 nM
Beside the measured number, compound 4's estimate is 2.4-fold (0.39 log units) below it; low and high end bracket the measured number.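

No new step can be read from compound 3 to compound 4, because compound 3 has only a limit in this assay: the limit of > 5000 nM in this assay, at which 1 of the 4 values shown sits.

The compounds shown leave open whether methoxy in place of hydrogen on an aromatic carbon, ortho to a large group, shifts the number on the core of compound 3 at all.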